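The compounds below may be only part of what the source reports. "The series", "measured", "known", "first", "only" and "open" are said of these compounds alone.

Measured so far, in a functional assay on BXPC-3 cells (Homo sapiens) for inhibition, read by MTT assay, with a stated time of 72 h; a higher number here means a weaker inhibitor, a lower number a stronger inhibitor:

Compound 1, `Cc1cnc(C(=O)Nc2cc(OCCNC(=O)OC(C)(C)C)cc3cccnc23)cn1` — in this assay compound 1 gives 3670 nM.
Compound 2, `Cc1cnc(C(=O)Nc2cc(OCCC3CCNCC3)cc3cccnc23)cn1` — in this assay compound 2 gives 8330 nM.

Compound 2 carries the highest of the two numbers shown; its nearest neighbour is compound 1, and the only measured step, a 2.3-fold higher number from compound 1 to compound 2 (0.36 log units; beyond the scatter), links the two through a change on the chain carbon and leaves the amide-bound aromatic ring untouched.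

Compound 3, `O=C(Nc1cc(OCCC2CCNCC2)cc2cccnc12)c1ncccn1`, differs from compound 2 at that other end: pyrimidin-2-yl in place of 5-methylpyrazin-2-yl on a carbonyl carbon. Going by the values given here, no measured step bears on this change, since both measured compounds share the same 5-methylpyrazin-2-yl group. With nothing to go on but the change itself, a step of no size beyond the scatter is expected, a 1.1-fold higher number from compound 2 to compound 3 (0.03 log units; within the scatter), with a wide range around it. Compound 3 is therefore estimated at 9000 nM, within 3500 nM to 25000 nM.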

Compound 3, half-maximal inhibitory concentration: > 10000 nM
Compound 3: only a limit was reported; the forecaster's own chance of this, stated with the estimate: 10%; middle value at least 1.1-fold (0.04 log units) from the limit.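

In this assay compound 3 gives > 10000 nM, which is a limit of the assay and not a number. Going by these compounds alone, the step on the carbonyl carbon, an at least 1.2-fold higher number from compound 2 to compound 3 (0.07 log units; that floor lies within the scatter), is the first reading at this end of the molecule; it shows that pyrimidin-2-yl in place of 5-methylpyrazin-2-yl brings no gain, but as a floor it cannot show how large any loss is. The swap removes one heavy atom and leaves the hydrogen-bond donors and acceptors unchanged in count, and the reading stops at the top of the measured range: the limit of > 10000 nM in this assay, at which 1 of the 3 values shown sits.

The change moves the ring nitrogens and drops the methyl group together, and a plain pyrazin-2-yl group on the carbonyl carbon would be needed to tell these apart. As far as these compounds go, whether pyrimidin-2-yl behaves alike with the (tert-butoxycarbonyl)amino chain of compound 1 remains open.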